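Swapping Nitro for Methoxy: Expected Cytotoxicity Shift

The source may report more compounds than this note shows. Statements on the series, on what has been measured and on what is new or still open speak of the compounds shown alone.

Going by the values given here, compound 2 `O=c1c(O)c(-c2ccccc2)oc2cc(OCc3ccccc3[N+](=O)[O-])cc(O)c12` is the only compound with a firm number in an ADME assay on Huh-5-2 cells (Homo sapiens) for cytotoxicity, read by WST assay, with a stated time of 3 days; a lower number here means that less compound is tolerated, a higher number that more compound is tolerated: in this assay compound 2 gives 32000 nM. Compound 1 `O=c1c(O)c(-c2ccccc2)oc2cc(OCc3ccccc3Br)cc(O)c12` reaches only a limit of the assay, > 100000 nM, namely (the limit of > 100000 nM in this assay, at which 1 of the 2 values shown sits). Among the compounds with values here, the single measured step, an at least 3.1-fold lower number from compound 1 to compound 2 (0.49 log units; beyond the scatter), concerns nitro in place of bromo. Compound 3 `COc1ccccc1COc1cc(O)c2c(=O)c(O)c(-c3ccccc3)oc2c1` differs from compound 2 by methoxy in place of nitro on an aromatic carbon. Within the data shown here, no measured step covers methoxy in place of nitro; the only evidence is that the nitro group arriving lowered the number. Its departure is therefore expected to push the number back up, a step of a 2.2-fold higher number from compound 2 to compound 3 (0.34 log units; beyond the scatter) toward the limit. Compound 3 is expected to give about 70000 nM, between 25000 nM and 150000 nM.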

Compound 3, half-maximal cytotoxic concentration: > 100000 nM
Compound 3 was reported as a limit (the forecaster's own chance of this, stated with the estimate: 40%); middle value at least 1.4-fold (0.15 log units) away from the limit.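

Putting methoxy in place of nitro on this aromatic carbon gives an at least 3.1-fold higher number from compound 2 to compound 3 (0.49 log units; beyond the scatter) in this assay. Of the three groups shown at this place, only nitro brings a firm number, while compound 1 and compound 3 both stand at a limit of the assay: the limit of > 100000 nM in this assay, at which 2 of the 3 values shown sit. The two limits leave the step between compound 1 and compound 3 unreadable, so bromo and methoxy cannot be ranked.

As far as these compounds go, whether the lower number is special to nitro remains open, since a nitrile or an amine at this place could fall on either side of the limit. From the compounds shown here alone, how much compound is tolerated beyond the limit also remains unknown for compound 1 and compound 3.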